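Replacing the 4-hydroxy-3-methoxyphenyl group in compound 3

A few compounds are considered here, and "the series" means these few. Any claim that something is new, unique, unknown or untested is made for them only; others in the source may bear on it.

Growth inhibition measured in a functional assay on A549 cells (Homo sapiens) for inhibition, read by sulforhodamine B assay, with a stated time of 48 h; a higher number here means a weaker inhibitor of growth, a lower number a stronger inhibitor of growth:
- Compound 1 `Cc1ccc(/C=C/C(=O)/C=C(O)/C=C/c2ccc(C)o2)o1`: > 25000 nM (a limit of the assay)
- Compound 2 `COc1ccc(/C=C/C(=O)/C=C/c2cc(OC)c(OC)c(OC)c2)cc1OC`: 1210 nM
- Compound 3 `COc1cc(C=C(C(=O)/C=C/c2ccc(OC)c(OC)c2)C(=O)/C=C/c2ccc(OC)c(OC)c2)ccc1O`: 530 nM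

Compound 1 gives only a limit in this assay, > 25000 nM, and no number. Among the two true numbers, compound 3 holds the lower, 530 nM, and the gap to compound 2 at 1210 nM lies beyond the scatter.

Compound 4 `COc1ccc(C=C(C(=O)/C=C/c2ccc(OC)c(OC)c2)C(=O)/C=C/c2ccc(OC)c(OC)c2)c(OC)c1` has not yet been measured. It carries 2,4-dimethoxyphenyl in place of 4-hydroxy-3-methoxyphenyl on a double-bonded chain carbon bound to a double-bonded chain carbon. Among the measured compounds shown here, no pair of measured compounds isolates this change, so the expectation is cautious: no step clearly beyond the scatter, with a slight lean toward a higher number in this assay. The expected size of the change is a 1.5-fold higher number from compound 3 to compound 4 (0.18 log units; within the scatter). Compound 4 is estimated at 800 nM, with an expected range from 300 nM to 2200 nM.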

Compound 4, concentration for 50% growth inhibition: 650 nM
Estimate against measurement, compound 4: 1.2-fold (0.09 log units) above; the range from low to high includes it.
By their numbers in this assay, from the lowest: compounds 3, 4 and 2 (each within the scatter of the next, the first and the last beyond it). At a limit, above all of these: compound 1.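

In this assay, among the compounds shown here, the step of a 1.2-fold higher number from compound 3 to compound 4 (0.09 log units; within the scatter) is the first one that can be read at this position, as the earlier compounds offered no pair differing in one place. On a double-bonded chain carbon bound to a double-bonded chain carbon, 2,4-dimethoxyphenyl takes the place of 4-hydroxy-3-methoxyphenyl, and the hydrogen-bond donor count falls from 1 to 0, yet the two numbers stay within the scatter of each other. Nothing in the data shown explains this outcome.

What this one pair leaves open is whether the same holds for other groups at this place, such as an aminophenyl group, a carboxylic acid or a longer chain. It also leaves open how the two remaining 3,4-dimethoxyphenyl arms of the shared core contribute to the growth inhibition.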